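A few compounds are considered here, and "the series" means these few. Any claim that something is new, unique, unknown or untested is made for them only; others in the source may bear on it.

Measured compounds:
compound 1, `COC(=O)/C(=C\c1ccc(OC(=O)c2cccc(OC)c2)cc1)Sc1ccnc2cc(Cl)ccc12`: 33300 nM
compound 2, `COC(=O)/C(=C\c1ccc(OC(=O)c2cccc(OC)c2OC)cc1)Sc1ccnc2cc(Cl)ccc12`: 25800 nM

In a functional assay on Jurkat E6.1 cells (Homo sapiens) for cytotoxicity, read by MTT assay, with a stated time of 24 h (on this read-out higher numbers stand for weaker inhibition and lower numbers for stronger inhibition), compound 2 gives 25800 nM, the lower of the two numbers shown, though the gap to compound 1 is within the scatter: compound 1 gives 33300 nM in this assay, and a 1.3-fold lower number from compound 1 to compound 2 (0.11 log units; within the scatter). Compound 3, `COC(=O)/C(=C\c1ccc(OC(=O)c2ccc(OC)c(OC)c2OC)cc1)Sc1ccnc2cc(Cl)ccc12`, is not yet measured in this assay. It differs from compound 2 by methoxy in place of hydrogen on an aromatic carbon. Among the measured compounds shown here, only one measured step bears on this change, the earlier methoxy addition in this assay, and a 1.3-fold lower number from compound 1 to compound 2 (0.11 log units; within the scatter). For the measured compounds named here, there is no second example of a third methoxy on this ring, so nothing points to a larger effect. A further methoxy is therefore expected to move the number little, if at all, beyond the scatter; the expected step is a 1.2-fold lower number from compound 2 to compound 3 (0.07 log units; within the scatter). Compound 3 is estimated at 22000 nM, with a range of 9000 nM to 55000 nM.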

Compound 3, half-maximal inhibitory concentration: 2410 nM
For compound 3 the middle estimate is 9.1-fold (0.96 log units) above the measured one, outside the stated range (below it).
By their numbers in this assay, from the lowest: compound 3; then compounds 2 and 1 (each within the scatter of the next).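

In this assay, methoxy in place of hydrogen at the carbon ortho to a methoxy group and para to a large group gives an 11-fold lower number from compound 2 to compound 3 (1.03 log units; beyond the scatter), whereas the same replacement elsewhere on this ring gives a 1.3-fold lower number from compound 1 to compound 2 (0.11 log units; within the scatter), so the size of the step depends on where the methoxy enters. Across the whole change, 2,3,4-trimethoxyphenyl in place of 3-methoxyphenyl gives a 14-fold lower number from compound 1 to compound 3 (1.14 log units; beyond the scatter), and only the step to compound 3 lies beyond the scatter. No supporting measurement accounts for the size of this step.

On these data alone, it remains open whether a methoxy at this carbon would give a similar step without the other two methoxy groups on the ring. As far as these compounds go, it is also open whether an ethoxy, a hydroxyl or a fluorine at this carbon would match it.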